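Methylpiperazine in Place of Benzyl(methyl)amine on the Side Chain

A few compounds are considered here, and "the series" means these few. Any claim that something is new, unique, unknown or untested is made for them only; others in the source may bear on it.

Compound 3 `CN(Cc1ccccc1)Cc1nc2ccccc2c(-c2ccccc2)c1C(=O)NCc1cc(C(F)(F)F)cc(C(F)(F)F)c1` gives 180 nM in an in vitro assay on UC11MG cells for binding affinity to Substance-P receptor (Homo sapiens), read by radioligand binding (on this read-out higher numbers stand for weaker inhibition and lower numbers for stronger inhibition), the higher of the two numbers measured. Compound 2 `NCc1nc2ccccc2c(-c2ccccc2)c1C(=O)NCc1cc(C(F)(F)F)cc(C(F)(F)F)c1` gives 0.0017 nM, and a 110000-fold higher number from compound 2 to compound 3 (5.02 log units; beyond the scatter) separates the two. Compound 1 `O=C(NCc1cc(C(F)(F)F)cc(C(F)(F)F)c1)c1cnc2ccccc2c1-c1ccccc1` reaches only a limit of this assay, > 1000 nM. The steps of an at least 5.5-fold lower number from compound 1 to compound 3 (0.74 log units; beyond the scatter) and an at least 580000-fold lower number from compound 1 to compound 2 (5.76 log units; beyond the scatter) show that both amines improve on hydrogen, the primary amine by far the more. Compound 4 `CN1CCN(Cc2nc3ccccc3c(-c3ccccc3)c2C(=O)NCc2cc(C(F)(F)F)cc(C(F)(F)F)c2)CC1` differs from compound 3 by 4-methylpiperazin-1-yl in place of benzyl(methyl)amino on a saturated chain carbon bound to an aromatic carbon. The change keeps a tertiary amine yet drops the benzyl group. Since compound 2 gives 0.0017 nM and compound 3 gives 180 nM, a move toward compound 2 is expected, with an 18-fold lower number from compound 3 to compound 4 (1.26 log units; beyond the scatter) as the estimated step. Compound 4 is expected to give 10 nM, between 0.3 nM and 300 nM.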

Compound 4, half-maximal inhibitory concentration: > 1000 nM
Compound 4 gave a limit, no number; the forecaster's own chance of this, stated with the estimate: 5%; middle value at least 100-fold (2.00 log units) from the limit.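

In this assay, a tertiary amine on this side chain does not by itself keep the gain over hydrogen: 4-methylpiperazin-1-yl in place of benzyl(methyl)amino gives an at least 5.5-fold higher number from compound 3 to compound 4 (0.74 log units; beyond the scatter). Set against the primary amine, the same position gives an at least 580000-fold higher number from compound 2 to compound 4 (5.76 log units; beyond the scatter), so the read-out here depends strongly on which amine is carried. The step from compound 1 to compound 4 cannot be read, because both stand at a limit: the limit of > 1000 nM in this assay, at which 2 of the 4 values shown sit.

From the compounds shown here alone, how a methylamino group or a morpholine ring would read on this saturated chain carbon remains open. So does the size of the loss for compound 4, whose reading is a limit and not a number.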